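A few compounds are considered here, and "the series" means these few. Any claim that something is new, unique, unknown or untested is made for them only; others in the source may bear on it.

Measured in a functional assay on SK-OV-3 cells (Homo sapiens) for antiproliferative activity, read by MTT assay, with a stated time of 24 h; on this read-out lower numbers stand for stronger inhibition and higher numbers for weaker inhibition:
- compound 1 `COc1ccc(C(=O)/C=C/c2ccc(F)cc2)c2c1C=CC(C)(C)O2`: > 10000 nM, a limit
- compound 2 `COc1ccc(C(=O)/C=C/c2ccc(Cl)cc2)c2c1C=CC(C)(C)O2`: > 10000 nM, a limit
- compound 3 `COc1ccc(C(=O)/C=C/c2ccc(O)cc2)c2c1C=CC(C)(C)O2`: > 10000 nM, a limit

Compound 3 has no numerical value, only the limit > 10000 nM. The series as a whole is described by the limit of > 10000 nM in this assay, at which 3 of the 3 values shown sit, so no ranking of these compounds can be made.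

The next comparison is with compound 4 `CCOc1cc(/C=C/C(=O)c2ccc(OC)c3c2OC(C)(C)C=C3)ccc1O`, which carries ethoxy in place of hydrogen on an aromatic carbon, ortho to a hydroxy group and meta to a large group: ethoxy in place of hydrogen on an aromatic carbon. The hydroxy group of compound 3 is kept.

The closest measured changes are a step that the two limits leave unreadable from compound 1 to compound 3 and a step that the two limits leave unreadable from compound 2 to compound 3. The remaining one is a step that the two limits leave unreadable from compound 1 to compound 2. None of them has a readable size, and none introduces ethoxy, so they give no measure of this change and no direction for it.

In this assay, no step beyond the scatter is therefore expected, and the estimate stays close to the limit because of the limit of > 10000 nM in this assay, at which 3 of the 3 values shown sit. The expected change is a step that the limit leaves unreadable from compound 3 to compound 4. For compound 4 the estimated value is 12000 nM, with an expected range of 4000 nM to 40000 nM.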

Compound 4, half-maximal inhibitory concentration: > 10000 nM
Compound 4 was reported as a limit; the forecaster's own chance of this, stated with the estimate: 70%; the middle value does not contradict the limit.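

In this assay, compound 3 and compound 4 are both reported only as limits, so no size can be read for the change of ethoxy in place of hydrogen between them. The series stays at a single limit: the limit of > 10000 nM in this assay, at which 4 of the 4 values shown sit.

The compounds shown leave open how compound 1, compound 2, compound 3 and compound 4 rank against one another.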